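Sulfonyl isomers on the shared core: compound 3 to compound 4

This account rests on a few compounds, and the source may have more. Where it says the series, first, only, none or still open, it means among the compounds named here.

In an assay on isolated protein for activation of Insulin-degrading enzyme (Homo sapiens), read by fluorescence, with stated times of 10 min and 20 min (on this read-out lower numbers stand for an effect already at smaller amounts and higher numbers for an effect only at larger amounts of compound), compound 1 `O=C(CCCc1c[nH]c2ccccc12)NCCCn1ccnc1` gives 10000 nM; 89100 nM (2 entries); the two entries sit far apart, as the several entries of compound 1 in this assay, 10000 nM; 89100 nM (2 entries) shows, so compound 1 carries no single number. Compound 2 `CS(=O)(=O)n1cc(CCCC(=O)NCCCn2ccnc2)c2ccccc21` gives 26900 nM in this assay. Compound 3 `O=C(CCCc1cn(S(=O)(=O)c2cccc(F)c2)c2ccccc12)NCCCn1ccnc1` gives 10200 nM in this assay, the lowest of the two single numbers, with compound 2 its nearest neighbour. Within the data shown here, the one counted step, a 2.6-fold lower number from compound 2 to compound 3 (0.42 log units; beyond the scatter), puts 3-fluorophenyl in place of methyl on a sulfonyl sulfur.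

Compound 4 `O=C(CCCc1cn(S(=O)(=O)c2ccc(F)cc2)c2ccccc12)NCCCn1ccnc1` differs from compound 3 by 4-fluorophenyl in place of 3-fluorophenyl on a sulfonyl sulfur; the two hold the same atoms, joined differently. Among the measured compounds shown here, no measured step bears directly on this change: the only counted step, a 2.6-fold lower number from compound 2 to compound 3 (0.42 log units; beyond the scatter), exchanges methyl for a fluorophenyl and says nothing about which fluorophenyl isomer sits on the sulfonyl sulfur. With both compounds carrying a fluorophenylsulfonyl group on the same core, the expectation in this assay is a step of no size beyond the scatter, in either direction, and the expected step of a 1.0-fold lower number from compound 3 to compound 4 (0.01 log units; within the scatter) is set accordingly. Compound 4 is therefore estimated at 10000 nM in this assay, with a range from 4000 nM to 25000 nM.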

Compound 4, half-maximal effective concentration: 6760 nM
Estimate against measurement, compound 4: 1.5-fold (0.17 log units) above, within the range that was stated.
By their numbers in this assay, from the lowest: compounds 4 and 3 (each within the scatter of the next); then compound 2.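

Exchanging 3-fluorophenyl for 4-fluorophenyl on a sulfonyl sulfur gives a 1.5-fold lower number from compound 3 to compound 4 (0.18 log units; within the scatter), so in this assay the two isomers are not separated and the place of the fluorine on this phenyl has no readable effect so far. The exchange of methyl for 4-fluorophenyl on the same sulfur gives a 4.0-fold lower number from compound 2 to compound 4 (0.60 log units; beyond the scatter), which stands alongside a 2.6-fold lower number from compound 2 to compound 3 (0.42 log units; beyond the scatter). The earlier compounds shown here showed this exchange for one isomer only; now both fluorophenyl isomers lie beyond the scatter from the methyl sulfonyl compound, so the step holds for either of the two isomers, though it stays modest in size.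

On these data alone, whether an unsubstituted phenyl, 2-fluorophenyl, or a phenyl carrying a methoxy group or a carboxylic acid on the sulfonyl sulfur would stay at this level remains open, as does any reading of what the fluorine itself contributes. The contribution of the sulfonyl group as a whole also stays open, since the compound without it offers no single number as a reference: the several entries of compound 1 in this assay, 10000 nM; 89100 nM (2 entries)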